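A few compounds are considered here, and "the series" means these few. Any claim that something is new, unique, unknown or untested is made for them only; others in the source may bear on it.

Series values in a functional assay on MOLT-4 cells (Homo sapiens) for antiproliferative activity, read by cell counting, with a stated time of 2 days; a higher number here means a weaker inhibitor, a lower number a stronger inhibitor:
- compound 1 `COc1cc(C(=O)c2sc(Nc3ccccc3)nc2N)cc(OC)c1OC`: 6 nM
- compound 2 `COc1ccc(Nc2nc(N)c(C(=O)c3ccccc3)s2)cc1`: 230 nM
- compound 3 `Nc1nc(Nc2ccc(Cl)cc2)sc1C(=O)c1ccccc1`: > 10000 nM (a limit of the assay)

Not yet measured: compound 4 `COc1ccc(Nc2nc(N)c(C(=O)c3cc(OC)c(OC)c(OC)c3)s2)cc1`.

Compound 1, at 6 nM, has the lowest number in the series, and compound 2, at 230 nM, lies beyond the scatter from it. Compound 3 gives only a limit, > 10000 nM.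

Compound 4 differs from compound 1 as follows: methoxy in place of hydrogen on an aromatic carbon. This is methoxy in place of hydrogen on an aromatic carbon, para to a large group, so anilino becomes (4-methoxyphenyl)amino.

Going by the values given here, no measured step makes this exact change. The nearest is an at least 43-fold higher number from compound 2 to compound 3 (1.63 log units; beyond the scatter), a large step for chloro in place of methoxy at the same place. It shows that this place matters, but it starts from methoxy, not hydrogen, and compound 2 and compound 3 also differ from compound 1 elsewhere. Methoxy is tolerated in compound 2 at 230 nM, so no step beyond the scatter is expected in this assay, though a higher number remains possible.

The estimated step is a 1.3-fold higher number from compound 1 to compound 4 (0.12 log units; within the scatter). For compound 4 the expected value is 8 nM, with an estimated range of 1.5 nM to 50 nM.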

Compound 4, half-maximal inhibitory concentration: 480 nM
Compound 4: middle estimate off by 60-fold (1.78 log units), on the low side, outside the stated range (above it).
By their numbers in this assay, from the lowest: compound 1; then compound 2; then compound 4. At a limit, above all of these: compound 3.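

In this assay the change gives an 80-fold higher number from compound 1 to compound 4 (1.90 log units; beyond the scatter) and shows that methoxy in place of hydrogen, para to a large group, is not a silent change on the core of compound 1. The earlier step, an at least 43-fold higher number from compound 2 to compound 3 (1.63 log units; beyond the scatter), compared chloro with methoxy only, on a different core, so the comparison of methoxy with hydrogen is new and shows a second change at this place with a large effect. Nothing measured here bears on why this step is so large.

From the compounds shown here alone, whether the higher number follows from methoxy itself or would also come with fluoro, methyl, hydroxy or an amine at this place on the core of compound 1 stays open. Also open, going by these compounds, is whether chloro on that core would repeat the step seen with compound 3.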